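Phenylethynyl in place of aryl: outlook for compound 4

The compounds below may be only part of what the source reports. "The series", "measured", "known", "first", "only" and "open" are said of these compounds alone.

In an assay on CHO cells for antagonist activity at transient receptor potential cation channel subfamily V member 1 (Homo sapiens), read by FLIPR (a lower number here means a stronger inhibitor, a higher number a weaker inhibitor), compound 1 `CC(C(=O)NCc1ccc(C(F)(F)F)nc1-c1ccc(Cl)cc1)c1ccc(NS(C)(=O)=O)c(F)c1` gives 0.7 nM, compound 2 `CC(C(=O)NCc1ccc(C(F)(F)F)nc1-c1ccc(C(C)(C)C)cc1)c1ccc(NS(C)(=O)=O)c(F)c1` gives 0.5 nM and compound 3 `Cc1cc(-c2nc(C(F)(F)F)ccc2CNC(=O)C(C)c2ccc(NS(C)(=O)=O)c(F)c2)ccc1F` gives 0.4 nM. Compound 3 holds the lowest of the three numbers, yet all three sit within the scatter of one another: a 1.4-fold lower number from compound 1 to compound 2 (0.15 log units; within the scatter), a 1.8-fold lower number from compound 1 to compound 3 (0.24 log units; within the scatter) and a 1.3-fold lower number from compound 2 to compound 3 (0.10 log units; within the scatter). Compound 4 `CC(C(=O)NCc1ccc(C(F)(F)F)nc1C#Cc1ccccc1)c1ccc(NS(C)(=O)=O)c(F)c1` differs from compound 3 as follows: 2-phenylethynyl in place of 4-fluoro-3-methylphenyl on an aromatic carbon. Going by the values given here, no measured step replaces the aromatic ring at this position with a 2-phenylethynyl group; the three steps seen, all at this same aromatic carbon, exchanged one phenyl pattern for another and stayed within the scatter. For compound 4 a number near that of compound 3 is expected, a 3.8-fold higher number from compound 3 to compound 4 (0.57 log units; beyond the scatter). Going by these compounds, the change itself is untested here; the bounds are set wide. The estimate for compound 4 in this assay is 1.5 nM, between 0.3 nM and 8 nM.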

Compound 4, inhibition constant: 0.8 nM
For compound 4 the middle estimate is 1.9-fold (0.27 log units) above the measured one; low and high end bracket the measured number.
By their numbers in this assay, from the lowest: compounds 3, 2, 1 and 4 (each within the scatter of the next).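

In this assay the steps of a 2.0-fold higher number from compound 3 to compound 4 (0.30 log units; within the scatter) and a 1.6-fold higher number from compound 2 to compound 4 (0.20 log units; within the scatter) and a 1.1-fold higher number from compound 1 to compound 4 (0.06 log units; within the scatter) show that 2-phenylethynyl, with its triple bond outside aromatic rings, can stand in place of each of the three aryl groups at this position without leaving the scatter. The position next to the ring nitrogen has thus accepted more than an exchange of one phenyl pattern for another. Nothing at hand explains this result.

Still open, going by these compounds, is whether an amine, a carboxylic acid or a longer alkyl chain on this carbon would stay within the scatter. Also open, on these data alone, is whether chloro or tert-butyl on the phenyl of the 2-phenylethynyl group would do so.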